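Working notes on a small single-point displacement series

The source may report more compounds than this note shows. Statements on the series, on what has been measured and on what is new or still open speak of the compounds shown alone.

Measured so far:
- compound 1 `COc1ccc(-c2sc(N)c(C(=O)c3ccc(Cl)cc3)c2C)cc1`: 1%
- compound 2 `CC(C)(C)Cc1c(-c2ccccn2)sc(N)c1C(=O)c1ccc(Cl)cc1`: 1%
- compound 3 `CC(C)(C)Cc1c(-c2ccccc2)sc(N)c1C(=O)c1cccc(Cl)c1`: 5%

In an assay on CHO cells for displacement of a labelled ligand from adenosine receptor A3 (Homo sapiens), read by scintillation counting, tested at 10 uM (on this read-out lower numbers stand for less inhibition and higher numbers for more inhibition at the one concentration tested (going by the name of the read-out)), compound 1 gives 1%, compound 2 gives 1% and compound 3 gives 5%. All three numbers are small. Compound 2 sits together with compound 1 at the lower end of the three values, with no change between them at the digits printed; against compound 3 the gap stays within the scatter of this kind of measurement, so no order among the three can be read from these numbers.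

Compound 4 `CC(C)(C)Cc1c(-c2cn[nH]c2)sc(N)c1C(=O)c1ccc(Cl)cc1` has not been measured in this assay. It differs from compound 2 at one position:
1H-pyrazol-4-yl in place of pyridin-2-yl on an aromatic carbon

Among the measured compounds shown here, no step between measured compounds is available for a change of this kind. The three measured values all lie close to the floor of the read-out, and nothing among them points to a change in the group on that aromatic carbon moving the number out of the scatter. The expected step of a number 2 percentage points higher from compound 2 to compound 4 (within the scatter) in this assay is therefore none beyond the scatter. Compound 4 is estimated to give 3% in this assay, with a range from 0% to 12%.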

Compound 4, a percentage reported as inhibition, at one concentration (the size of the read-out at that concentration, not a potency): 1%
Compound 4: middle estimate off by 2 percentage points, on the high side; measured number inside the range.
By their numbers in this assay, from the lowest: compounds 1, 2, 4 and 3 (each within the scatter of the next).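

Working notes on the position next to the ring sulfur: in this assay, the exchange of pyridin-2-yl for 1H-pyrazol-4-yl on this aromatic carbon gives the first step between compounds that differ in one place, with no change at the digits printed from compound 2 to compound 4 (within the scatter) as its size. The exchange replaces a six-membered aromatic ring with a five-membered one and brings in a hydrogen-bond donor where the leaving group has none, yet the printed number stays the same, so this particular change leaves the read-out where it was at the one concentration tested. Nothing in the material available accounts for this result or links it to any property of either group.

The compounds shown leave open whether a group of another kind on the same aromatic carbon, such as an amine, a carboxylic acid or a longer chain, would lift the number out of the scatter. They also leave open whether any change elsewhere on the shared core, such as an amide in place of the amino group, would do so, since this single step speaks only for these two groups in this one setting.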